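The compounds below may be only part of what the source reports. "The series", "measured", "known", "first", "only" and "open" are said of these compounds alone.

Compound 1 `COc1ccc(C2=NN(C3=NC(=O)/C(=C4\C(=O)Nc5ccccc54)S3)C(c3ccc(OC)cc3)C2)cc1` and compound 2 `COc1ccc(C2=NN(C3=NC(=O)/C(=C4\C(=O)Nc5ccc(Br)cc54)S3)C(c3ccc(OC)cc3)C2)cc1` share one core and differ only in the change (bromo in place of hydrogen on an aromatic carbon). In a functional assay on cells (Melanoma cell, Homo sapiens) for cytotoxicity, read by sulforhodamine B assay, with a stated time of 48 h (on this read-out lower numbers stand for stronger inhibition of growth and higher numbers for weaker inhibition of growth), compound 1 gives 100000 nM. In this assay compound 2 gives 410 nM. The step between them is a 240-fold lower number from compound 1 to compound 2 (2.39 log units; beyond the scatter).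

Compound 3 `CN(C)c1ccc(C2CC(c3ccccc3)=NN2C2=NC(=O)/C(=C3\C(=O)Nc4ccccc43)S2)cc1` carries a different core; the difference between the two cores is not broken down here. In this assay compound 3 gives 29400 nM, a number that lies between those of compound 1 and compound 2.

Compound 4 `CN(C)c1ccc(C2CC(c3ccccc3)=NN2C2=NC(=O)/C(=C3\C(=O)Nc4ccc(Br)cc43)S2)cc1` has not yet been measured. It differs from compound 3 by the change (bromo in place of hydrogen on an aromatic carbon), the same change that carries compound 1 to compound 2, made at the same place. Among the compounds shown this change occurs only twice, so the expectation for compound 4 rests on a single earlier example. Since compound 1 stands at 100000 nM, the full size of the earlier step may partly reflect how weak compound 1 is, so the step for compound 4 is expected to be somewhat smaller. Compound 4 is therefore expected to show a step of a 98-fold lower number from compound 3 to compound 4 (1.99 log units; beyond the scatter). On that basis compound 4 is estimated to give about 300 nM in this assay, with a plausible range from 60 nM to 3000 nM.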

Compound 4, concentration for total growth inhibition: 460 nM
Beside the measured number, compound 4's estimate is 1.5-fold (0.19 log units) below it; measured number inside the range.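

In this assay, bromo in place of hydrogen on an aromatic carbon gives a 64-fold lower number from compound 3 to compound 4 (1.81 log units; beyond the scatter), so on the core of compound 3 the change again lowers the number by a large step, in the same direction as on the core of compound 1. The direction carries from one core to the other, but the size does not carry over unchanged, since the two steps differ by more than the scatter: the same change on two cores in this assay, a 240-fold lower number (2.39 log units; beyond the scatter) from compound 1 to compound 2 and a 64-fold lower number (1.81 log units; beyond the scatter) from compound 3 to compound 4, 3.8-fold (0.58 log units) apart, beyond the scatter of two such steps These two pairs show that the change can be carried between these two cores with a large lowering of the number on each, but they do not show which of the differences between the cores goes with the difference in step size, nor whether a third core would behave in the same way.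

Across the compounds shown, only hydrogen and bromo appear at this place on the ring, so it remains open whether chloro, fluoro or nitro there would give a step of similar size on either core. On these data alone, it also remains open whether the step seen in these melanoma cells would appear in other cell types.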